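A few compounds are considered here, and "the series" means these few. Any claim that something is new, unique, unknown or untested is made for them only; others in the source may bear on it.

Measured so far in an ADME assay on MT4 cells (Homo sapiens) for cytotoxicity, read by MTT assay, with a stated time of 4 days; a lower number here means that less compound is tolerated, a higher number that more compound is tolerated:

compound 1 `Cc1cccc(Oc2nc(Nc3ccc(C#N)cc3)nc3ccccc23)c1` gives 355000 nM
compound 2 `N#Cc1ccc(Nc2nc(Oc3ccc(Cl)cc3)c3ccccc3n2)cc1` gives 198000 nM
compound 3 `Cc1cc(Br)cc(Br)c1Oc1nc(Nc2ccc(C#N)cc2)nc2ccccc12` gives 150000 nM

Compound 3 has the lowest number of the three in this assay. Its gap to compound 2 is within the scatter; its gap to compound 1, a 2.4-fold lower number from compound 1 to compound 3 (0.37 log units; beyond the scatter), is beyond the scatter and modest. The step of a 1.3-fold lower number from compound 2 to compound 3 (0.12 log units; within the scatter) is also within the scatter, so among the three only compound 1 is set apart from compound 3.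

Compound 4 `Cc1ccccc1Oc1nc(Nc2ccc(C#N)cc2)nc2ccccc12` differs from compound 3 in one place: 2-methylphenyl in place of 2,4-dibromo-6-methylphenyl on an oxygen on an aromatic ring. The step that bears on this is a 2.4-fold lower number from compound 1 to compound 3 (0.37 log units; beyond the scatter), where the dibromo-methylphenyl entered in place of a methylphenyl and the number fell modestly; compound 4 reverses that entry, keeping a methylphenyl without the bromines. The step from compound 2 to compound 3 says only that a chlorophenyl and the dibromo-methylphenyl sit within the scatter of each other.

For the measured compounds named here, the expectation for compound 4 is therefore a modest rise back toward the number of compound 1, a 2.0-fold higher number from compound 3 to compound 4 (0.30 log units; within the scatter), because a 2.4-fold lower number from compound 1 to compound 3 (0.37 log units; beyond the scatter) is the only step beyond the scatter here. Compound 4 is estimated at 300000 nM in this assay, with a range of 150000 nM to 600000 nM.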

Compound 4, half-maximal cytotoxic concentration: 355000 nM
For compound 4 the middle estimate is 1.2-fold (0.07 log units) below the measured one; measured number inside the range.
By their numbers in this assay, from the lowest: compounds 3, 2, 1 and 4 (each within the scatter of the next, the first and the last beyond it).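

In this assay, 2-methylphenyl in place of 2,4-dibromo-6-methylphenyl on the oxygen gives a 2.4-fold higher number from compound 3 to compound 4 (0.37 log units; beyond the scatter), so the step beyond the scatter now appears with a methylphenyl group on both sides of a change that takes out only the two bromines. 2-Methylphenyl in place of 3-methylphenyl gives no change at the digits printed from compound 1 to compound 4 (within the scatter), and 2-methylphenyl in place of 4-chlorophenyl gives a 1.8-fold higher number from compound 2 to compound 4 (0.25 log units; within the scatter), so neither of these two changes on the oxygen is resolved from the scatter, and among the compounds shown only the dibromo compound 3 stands apart, from compound 1 and compound 4. No measurement shown bears on why the number moves with the bromines.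

Open, on these data alone, is whether a single bromine would give the same step or both are needed. Also open, as far as these compounds go, is where an unsubstituted phenyl, or a phenyl carrying an amine or a carboxylic acid, would fall at this position.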